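From Ethyl to Fluorophenyl on the Ring Nitrogen

A few compounds are considered here, and "the series" means these few. Any claim that something is new, unique, unknown or untested is made for them only; others in the source may bear on it.

In a functional assay on 143B cells (Homo sapiens) for inhibition, read by CCK-8 assay, with a stated time of 72 h, tested at 1 uM (on this read-out lower numbers stand for less inhibition and higher numbers for more inhibition at the one concentration tested (going by the name of the read-out)), compound 2 `CCN1C(=O)CSC1c1cccc(C(=O)NCCCCc2ccccc2)c1` gives 40%, the higher of the two numbers at hand; compound 1 `COc1ccc(OC)c(N2C(=O)CSC2c2cccc(C(=O)NCCCCc3ccccc3)c2)c1` gives 2%. Compound 3 `O=C(NCCCCc1ccccc1)c1cccc(C2SCC(=O)N2c2cccc(F)c2)c1` differs from compound 2 in one place: 3-fluorophenyl in place of ethyl on an amide-type nitrogen in a ring. Within the data shown here, the one measured step that bears on this, a number 38 percentage points higher from compound 1 to compound 2 (beyond the scatter), exchanged an aryl group for ethyl on an amide-type nitrogen in a ring. Compound 3 brings an aryl group back there, so a drop is expected; the 3-fluorophenyl is not the 2,5-dimethoxyphenyl of compound 1, so its size is uncertain. The expected step is a number 25 percentage points lower from compound 2 to compound 3 (beyond the scatter). Compound 3 is estimated at 15%, between 0% and 40%.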

Compound 3, a percentage reported as inhibition, at one concentration (the size of the read-out at that concentration, not a potency): 63%
Estimate against measurement, compound 3: 48 percentage points below; the whole stated range lies below it.
By their numbers in this assay, from the lowest: compound 1; then compound 2; then compound 3.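

Placing an aryl group on this amide-type nitrogen in a ring gave a number 23 percentage points higher from compound 2 to compound 3 (beyond the scatter) in this assay, so an aryl group there does not by itself lower the number. The two aryl groups also stand far apart, with a number 61 percentage points higher from compound 1 to compound 3 (beyond the scatter) on going from 2,5-dimethoxyphenyl to 3-fluorophenyl, so among these compounds the kind of aryl group matters and not just its presence. Nothing measured here explains the difference between these groups.

Left open is how a plain phenyl on this nitrogen would compare with 3-fluorophenyl, which would speak to the part played by the fluorine. Also open, going by these compounds, is whether a benzyl group or a longer chain there would rank nearer ethyl or 3-fluorophenyl.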